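Swapping an Indole for Dichlorophenyl on a Lactam Nitrogen

The source may hold more compounds than are shown below. What is called first, only, known or untested is meant among the compounds shown, and "the series" means these compounds.

Three compounds, each carrying an aromatic group on a ring nitrogen, were tested in a functional assay on SK-N-SH cells (Homo sapiens) for cytotoxicity, read by sulforhodamine B assay, with a stated time of 48 h; on this read-out higher numbers stand for weaker inhibition and lower numbers for stronger inhibition. Compound 1 `CO[C@@H]1CC=C2NN(c3cc(Cl)cc(Cl)c3)C(=O)CC[C@]2(c2ccccc2)O1` bears a 3,5-dichlorophenyl group on a ring nitrogen of a somewhat different core, and in this assay compound 1 gives 7110 nM. Compound 2 `CO[C@@H]1CC=C2N(c3ccccn3)C(=O)C[C@]2(c2ccccc2)O1` has a pyridin-2-yl group on an amide-type nitrogen in a five-membered ring, and in this assay compound 2 gives 5100 nM. Compound 3 `CO[C@@H]1CC=C2N(c3ccc4[nH]ccc4c3)C(=O)C[C@]2(c2ccccc2)O1` carries a 1H-indol-5-yl group at that same nitrogen, and in this assay compound 3 gives 4400 nM. Compound 3 sits at the low end of these three numbers, but its gaps to compound 2 and to compound 1 both lie within the scatter. Going by the values given here, the only step that exchanges one aromatic group for another on this nitrogen, a 1.2-fold lower number from compound 2 to compound 3 (0.06 log units; within the scatter), was within the scatter.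

Compound 4 `CO[C@@H]1CC=C2N(c3cc(Cl)cc(Cl)c3)C(=O)C[C@]2(c2ccccc2)O1` takes the next step: 3,5-dichlorophenyl in place of 1H-indol-5-yl on an amide-type nitrogen in a ring. Among the compounds with values here, only the step from compound 2 to compound 3 bears directly on it, and that step was within the scatter; compound 1 further shows that a 3,5-dichlorophenyl group on a related core gives a number in the same region. The step from compound 3 to compound 4 is therefore expected to be a 1.3-fold higher number from compound 3 to compound 4 (0.10 log units; within the scatter), not clearly beyond the scatter. Compound 4 is estimated to give 5500 nM in this assay, within a range from 2000 nM to 15000 nM.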

Compound 4, half-maximal inhibitory concentration: 9670 nM
Compound 4: the middle estimate sits 1.8-fold (0.25 log units) below what was measured; the measured number falls inside the stated range.
By their numbers in this assay, from the lowest: compounds 3, 2, 1 and 4 (each within the scatter of the next, the first and the last beyond it).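

In this assay, going by these compounds alone, the exchange of 1H-indol-5-yl for 3,5-dichlorophenyl on the amide-type nitrogen gives a 2.2-fold higher number from compound 3 to compound 4 (0.34 log units; beyond the scatter) and so provides the first step at this position to clear the usual scatter, showing that the aromatic group placed here can shift the number, though only modestly. The same 3,5-dichlorophenyl group in place of pyridin-2-yl gives a 1.9-fold higher number from compound 2 to compound 4 (0.28 log units; within the scatter) and stays inside the scatter, so among these three groups on the shared core, only the indole and dichlorophenyl compounds can be told apart. No accompanying measurement bears on what lies behind this shift.

Going by these compounds, all three groups compared on this nitrogen are aromatic rings, so it remains open how the number would respond to a non-aromatic substituent there, such as a short alkyl chain or a chain ending in an amine or a carboxylic acid. On these data alone, it also remains open whether a single chlorine on the phenyl ring would give a number closer to that of compound 3 or to that of compound 4.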